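A few compounds are considered here, and "the series" means these few. Any claim that something is new, unique, unknown or untested is made for them only; others in the source may bear on it.

Compound 2 `CN(C)CCn1cnnc1-c1cc(Oc2ccc(NC(=O)N/N=C/c3cccc(Br)c3)cc2F)ccn1`: 970 nM
Compound 1 `CN(C)CCn1cnnc1-c1cc(Oc2ccc(NC(=O)N/N=C/c3ccc(O)c(O)c3)cc2F)ccn1`: a limit, > 100000 nM

In a functional assay on A549 cells (Homo sapiens) for cytotoxicity, read by MTT assay, with a stated time of 72 h (on this read-out lower numbers stand for stronger inhibition and higher numbers for weaker inhibition), compound 2 gives 970 nM, the only plain number shown. For compound 1 the result is only the assay limit of > 100000 nM, not a number, as noted in the limit of > 100000 nM in this assay, at which 1 of the 2 values shown sits. Among the compounds with values here, the single measured step, an at least 100-fold lower number from compound 1 to compound 2 (2.01 log units; beyond the scatter), bears on the change to compound 3 `CN(C)CCn1cnnc1-c1cc(Oc2ccc(NC(=O)N/N=C/c3cccc(O)c3)cc2F)ccn1`, which is hydroxy in place of bromo on an aromatic carbon. Because that step an at least 100-fold lower number from compound 1 to compound 2 (2.01 log units; beyond the scatter) was large when hydroxy groups gave way to bromo, returning one hydroxy is expected to raise the number, and the step from compound 2 to compound 3 is expected to be a 15-fold higher number from compound 2 to compound 3 (1.19 log units; beyond the scatter). Compound 3 is therefore estimated at 15000 nM, within a range from 2500 nM to 100000 nM.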

Compound 3, half-maximal inhibitory concentration: > 100000 nM
Compound 3: a limit, no number; the forecaster's own chance of this, stated with the estimate: 35%; middle value at least 6.6-fold (0.82 log units) from the limit.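

In this assay, hydroxy on this aromatic carbon, meta to a large group, does not keep the low number seen with bromo: the change gives an at least 100-fold higher number from compound 2 to compound 3 (2.01 log units; beyond the scatter). Compound 3 stands at a limit of the assay, > 100000 nM, not a number. A single hydroxy in place of bromo is thus enough to reach the same limit as compound 1, which carries two hydroxy groups.

Whether compound 1 and compound 3 differ cannot be read: the limit of > 100000 nM in this assay, at which 2 of the 3 values shown sit.

Going by these compounds, how a methoxy group, a chlorine atom or an amine on this carbon would read stays open.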